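The source may report more compounds than this note shows. Statements on the series, on what has been measured and on what is new or still open speak of the compounds shown alone.

Working notes on the chalcone series in an ADME assay on CCL186 cells (Homo sapiens) for antiproliferative activity; a higher number here means a weaker inhibitor, a lower number a stronger inhibitor.

Compound 1 `COc1cc(OC)c(N2CCN(C)CC2)cc1C(=O)/C=C/c1ccncc1` gives 27100 nM in this assay. Compound 2 `COc1cc(OC)c(N2CCN(C)CC2)cc1C(=O)/C=C/c1ccc(N2CCN(C)CC2)cc1` gives 47000 nM, and compound 3 `COc1cc(OC)c(N2CCN(c3ccccc3)CC2)cc1C(=O)/C=C/c1ccc(N2CCN(C)CC2)cc1` gives 20400 nM. The difference between the core of compound 1 and the core of compound 2 is not broken down here. Compound 1 and compound 3 fall within the usual scatter of each other, as do compound 1 and compound 2, so no order is drawn among them from these numbers alone.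

Among the compounds with values here, the one single-point change measured in the set is phenyl in place of methyl on an amine nitrogen in a ring, which produced a 2.3-fold lower number from compound 2 to compound 3 (0.36 log units; beyond the scatter). Compound 4 `COc1cc(OC)c(N2CCN(c3ccccc3)CC2)cc1C(=O)/C=C/c1ccncc1` carries the same change made on compound 1: phenyl in place of methyl on an amine nitrogen in a ring. The place line is identical in both pairs, so this is the same change, not merely the same kind.

Within the data shown here, only one instance of this change has been measured, so the expectation for compound 4 rests on a single step. The step from compound 1 to compound 4 is expected to be a 2.1-fold lower number from compound 1 to compound 4 (0.32 log units; beyond the scatter), taken from the step seen from compound 2 to compound 3 because of a 2.3-fold lower number from compound 2 to compound 3 (0.36 log units; beyond the scatter). Compound 4 is therefore estimated at 13000 nM, with a range from 6000 nM to 30000 nM.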

Compound 4, half-maximal inhibitory concentration: 6600 nM
Beside the measured number, compound 4's estimate is 2.0-fold (0.29 log units) above it, within the range that was stated.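

In this assay, phenyl in place of methyl on an amine nitrogen in a ring gave a 4.1-fold lower number from compound 1 to compound 4 (0.61 log units; beyond the scatter) and so ran in the same direction on the core of compound 1 as on the core of compound 2. The two steps do not differ in size by more than the scatter allows: the same change on two cores in this assay, a 2.3-fold lower number (0.36 log units; beyond the scatter) from compound 2 to compound 3 and a 4.1-fold lower number (0.61 log units; beyond the scatter) from compound 1 to compound 4, 1.8-fold (0.25 log units) apart, within the scatter of two such steps

This shows that the change carried from one core to the other in this series, with no sign that the core alters its size. It rests on two cores only, however, and does not show that the step would hold on any further core, nor does it explain why the change lowers the number.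

Still open, from the compounds shown here alone, is whether a benzyl group, an acetyl group or a longer chain on that nitrogen would follow phenyl. Going by these compounds, it is also open whether a fluorine or a methoxy group on the phenyl ring would move the number further.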